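This account rests on a few compounds, and the source may have more. Where it says the series, first, only, none or still open, it means among the compounds named here.

Compound 1 `COc1ccc(OC(=O)c2cn(-c3ccccc3)nc2-c2cccnc2)cc1` was tested in a functional assay on MCF7 cells (Homo sapiens) for cytotoxicity, read by MTT assay, with a stated time of 48 h (a higher number here means a weaker inhibitor, a lower number a stronger inhibitor), and gave only a limit, > 100000 nM, with no number behind it. That is the limit (the limit of > 100000 nM in this assay, at which 1 of the 3 values shown sits). Two companions share the same core. Compound 2 `CC(C)c1cccc(OC(=O)c2cn(-c3ccccc3)nc2-c2cccnc2)c1` gives 75500 nM in this assay. Compound 3 `O=C(Oc1ccc(-c2ccccc2)cc1)c1cn(-c2ccccc2)nc1-c1cccnc1` has no result in this assay, reported as "nd(insoluble)" (no result reported). Among the measured compounds shown here, the only measured step between compounds that differ in one place, an at least 1.3-fold lower number from compound 1 to compound 2 (0.12 log units; that floor lies within the scatter), concerns the group on the oxygen next to the carbonyl group and has a floor that lies within the scatter. Compound 4 `COc1ccc(OC(=O)c2cn(-c3ccccc3)nc2-c2ccncc2)cc1` has not yet been measured. It differs from compound 1 by pyridin-4-yl in place of pyridin-3-yl on an aromatic carbon. For the measured compounds named here, no measured step touches the pyridin-3-yl group, so the one measured step offers no guide of its own; it shows only that compound 1 sits at the limit of this assay and that a change elsewhere moved the number little. The step from compound 1 to compound 4 is therefore expected to be small, a step that the limit leaves unreadable from compound 1 to compound 4, with a real chance that compound 4 again shows only a limit. Compound 4 is estimated at 120000 nM in this assay, between 50000 nM and 300000 nM.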

Compound 4, half-maximal inhibitory concentration: > 100000 nM
Compound 4 ended at the assay's limit; the forecaster's own chance of this, stated with the estimate: 70%; the middle value is on the limit's open side.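

Compound 1 and compound 4 both sit at a limit, so the step between them cannot be read: the limit of > 100000 nM in this assay, at which 2 of the 4 values shown sit.

The compounds shown leave open whether pyridin-4-yl and pyridin-3-yl differ at all in this assay and how far past the limit either compound lies.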